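The compounds below may be only part of what the source reports. "The series", "measured", "known", "first", "only" and "open" are said of these compounds alone.

Working notes on the series. Going by the values given here, in a functional assay on the whole organism with Mus musculus as the target (a lower number here means that less compound is needed, a higher number that more compound is needed for the effect), compound 1 (`CN1C(=O)CCC1(O)c1cccc(C(F)(F)F)c1`) gives 51.6 mg/kg, the only true number so far. Compound 2 (`CN(C)C(=O)CCC(=O)c1cccc(C(F)(F)F)c1`) gives > 37.5 mg/kg, which is a limit of the assay and not a number. Its exact standing in this assay is therefore open, and the next step starts from that limit.

Compound 3 (`CC(C)CNC(=O)CCC(=O)c1cccc(C(F)(F)F)c1`) keeps the rest of compound 2 and differs in one place: isobutylamino in place of dimethylamino on a carbonyl carbon. This puts isobutylamino in place of dimethylamino on a carbonyl carbon. Among the compounds with values here, no measured step shows what such a change does, so no direction is favoured and no shift beyond the scatter is expected. The estimated step runs a step that the limit leaves unreadable from compound 2 to compound 3. A further limit rather than a number remains a real possibility. For compound 3 the expected value is 50 mg/kg, with an estimated range of 20 mg/kg to 130 mg/kg.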

Compound 3, dose for half-maximal effect: > 200 mg/kg
Compound 3 ended at the assay's limit; the forecaster's own chance of this, stated with the estimate: 45%; middle value at least 4.0-fold (0.60 log units) from the limit.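

Going by these compounds alone, compound 2 and compound 3 both stand at limits of this assay, and no step between them can be read. The compounds shown leave open whether isobutylamino in place of dimethylamino on a carbonyl carbon changes the dose needed at all, and in which direction.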